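The source may report more compounds than this note shows. Statements on the series, on what has been measured and on what is new or still open speak of the compounds shown alone.

Working notes on the series. Compound 1 `O=C(CCSC(=S)NCc1cccnc1)NCc1ccccc1` reaches only a limit in a functional assay on SK-BR-3 cells (Homo sapiens) for cytotoxicity, read by resazurin assay, with a stated time of 72 h (on this read-out lower numbers stand for stronger inhibition and higher numbers for weaker inhibition), namely > 100000 nM, the limit noted as the limit of > 100000 nM in this assay, at which 1 of the 3 values shown sits. Compound 2 `S=C(NCc1cccnc1)SCCc1noc(-c2ccccc2)n1` gives 1290 nM in this assay. Compound 3 `Fc1ccccc1-c1nnc(CCSC(=S)NCc2cccnc2)o1` gives 4690 nM in this assay, the highest of the two numbers, a gap beyond the scatter to compound 2. Compound 4 `S=C(NCc1cccnc1)SCCc1nnc(-c2ccc(Cl)cc2)o1` is not yet measured; it differs from compound 3 by 4-chlorophenyl in place of 2-fluorophenyl on an aromatic carbon. Among the compounds with values here, no step between measured compounds that differ in one place is available, so the size of this change cannot be read from the series; a step within or just beyond the scatter, toward a slightly lower number, is expected. Compound 4 is expected at 3000 nM in this assay, within 900 nM to 12000 nM. The step is estimated as a 1.6-fold lower number from compound 3 to compound 4 (0.19 log units; within the scatter).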

Compound 4, half-maximal inhibitory concentration: 860 nM
Beside the measured number, compound 4's estimate is 3.5-fold (0.54 log units) above it, outside the stated range (below it).
By their numbers in this assay, from the lowest: compounds 4 and 2 (each within the scatter of the next); then compound 3. At a limit, above all of these: compound 1.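

In this assay, within the data shown here, 4-chlorophenyl in place of 2-fluorophenyl gives a 5.5-fold lower number from compound 3 to compound 4 (0.74 log units; beyond the scatter), the first readable step. The aromatic carbon next to the ring nitrogen and next to the ring oxygen is therefore sensitive to which substituted phenyl it carries. No measurement shown accounts for this step.

The halogen and its place on the phenyl change together, so their contributions cannot be separated. Neither 4-fluorophenyl, 2-chlorophenyl nor a phenyl bearing a carboxylic acid appears at this position among the compounds shown.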